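Methyl to methoxy on the trifluoromethyl compound

A few compounds are considered here, and "the series" means these few. Any claim that something is new, unique, unknown or untested is made for them only; others in the source may bear on it.

So far, three compounds have been measured in a functional assay on MCF7 cells (Homo sapiens) for cytotoxicity, read by MTT assay, with a stated time of 24 h; a lower number here means a stronger inhibitor, a higher number a weaker inhibitor:

- Compound 1 `CCNc1cc(-c2ccc(NC(=O)Nc3ccc(C)cc3)cc2C)ccn1` gives 9210 nM
- Compound 2 `CCNc1cc(-c2ccc(NC(=O)Nc3cccc(Cl)c3)cc2C)ccn1` gives 4180 nM
- Compound 3 `CCNc1cc(-c2ccc(NC(=O)Nc3ccc(C)cc3)cc2C(F)(F)F)ccn1` gives 9470 nM

In this assay compound 3 stands within the scatter of compound 1 and apart only from compound 2, which has the lower number. Compound 4 `CCNc1cc(-c2ccc(NC(=O)Nc3ccc(OC)cc3)cc2C(F)(F)F)ccn1` carries methoxy in place of methyl on an aromatic carbon, para to a large group methoxy in place of methyl on an aromatic carbon in its difference from compound 3. Among the compounds with values here, no measured step makes this exchange. Trifluoromethyl in place of methyl gave a 1.0-fold higher number from compound 1 to compound 3 (0.01 log units; within the scatter), and 3-chlorophenyl in place of 4-methylphenyl, the group that changes here, gave only a modest 2.2-fold lower number from compound 1 to compound 2 (0.34 log units; beyond the scatter) in the same read-out. The expected step is therefore none beyond the scatter: a 1.2-fold lower number from compound 3 to compound 4 (0.07 log units; within the scatter) as estimated. Compound 4 is estimated at 8000 nM, with an expected range from 3500 nM to 18000 nM in this measurement.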

Compound 4, half-maximal inhibitory concentration: 5740 nM
Compound 4: middle estimate off by 1.4-fold (0.14 log units), on the high side; the range from low to high includes it.
By their numbers in this assay, from the lowest: compounds 2, 4, 1 and 3 (each within the scatter of the next, the first and the last beyond it).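

In this assay, methoxy in place of methyl on an aromatic carbon, para to a large group, gives a 1.6-fold lower number from compound 3 to compound 4 (0.22 log units; within the scatter). This is the first exchange shown that keeps the substituent at this place and changes only the group, and adding a hydrogen-bond acceptor there does not separate the two compounds beyond the scatter. Nothing available bears on the reason for this result.

As far as these compounds go, whether methoxy behaves the same way on compound 1, with its methyl in place of trifluoromethyl, remains open. So does the effect of an amine or a carboxylic acid at this place.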